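A few compounds are considered here, and "the series" means these few. Any claim that something is new, unique, unknown or untested is made for them only; others in the source may bear on it.

Measured compounds in a functional assay on CCRF-CEM cells (Homo sapiens) for cytotoxicity, read by cell counting, with a stated time of 3 days; on this read-out lower numbers stand for stronger inhibition and higher numbers for weaker inhibition:
compound 1 `Nc1cccc(/C=C2\SC(=O)N(Cc3cccc(Cl)c3)C2=O)c1` — 195000 nM
compound 2 `Nc1ccc(/C=C2\SC(=O)N(Cc3cccc(Cl)c3)C2=O)cc1` — 18000 nM

Going by the values given here, on these two numbers compound 2 holds the lowest value; its nearest neighbour is compound 1, and the only measured step, an 11-fold lower number from compound 1 to compound 2 (1.03 log units; beyond the scatter), separates them. That step moves the amino group on the ring attached to the exocyclic double bond and leaves the benzyl side untouched.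

Compound 3 `Nc1ccc(/C=C2\SC(=O)N(Cc3ccccc3)C2=O)cc1` is not yet measured. It differs from compound 2 by hydrogen in place of chloro on an aromatic carbon, that is, 3-chlorophenyl to phenyl on the benzyl substituent of the shared core. Among the compounds with values here, no measured step touches this part of the molecule, so the step from compound 1 to compound 2 gives no direct guidance on how the chloro removal will read in this assay; it only fixes the starting level of compound 2.

With nothing measured that bears on the chloro, the working expectation for compound 3 is a step not beyond the scatter, a 1.5-fold higher number from compound 2 to compound 3 (0.18 log units; within the scatter), leaning if anything toward a slightly higher number. Compound 3 is therefore estimated at 27000 nM, within a range from 8000 nM to 90000 nM.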

Compound 3, half-maximal inhibitory concentration: 42000 nM
Estimate against measurement, compound 3: 1.6-fold (0.19 log units) below, and the stated range covers the measured number.
By their numbers in this assay, from the lowest: compound 2; then compound 3; then compound 1.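

In this assay the benzyl side of the shared core now has its first reading, and going from 3-chlorophenyl to phenyl gives a 2.3-fold higher number from compound 2 to compound 3 (0.37 log units; beyond the scatter), so this position does respond to the change, with the chloro-bearing compound holding the lower number. Going by these compounds alone, until now the only readable change was the shift of the amino group, and that step, an 11-fold lower number from compound 1 to compound 2 (1.03 log units; beyond the scatter), is clearly the larger of the two, so on these compounds the placement of the amino group moves the read-out more than the loss of chloro does. No available data give a reason for the difference between chloro and hydrogen at this position.

Still open, as far as these compounds go, is whether the step belongs to chloro specifically or would also appear with another group on the same aromatic carbon, such as fluoro, bromo, methyl or methoxy. Also open, from the compounds shown here alone, is whether the chloro step has the same size when the amino group sits as in compound 1, and whether chloro elsewhere on the benzyl ring reads the same way.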